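The source may report more compounds than this note shows. Statements on the series, on what has been measured and on what is new or still open speak of the compounds shown alone.

Series notes, read in an assay on SH-SY5Y cells for inhibition of Voltage-dependent L-type calcium channel subunit alpha-1D (Homo sapiens), read by calcium flux, with a stated time of 15 min; on this read-out lower numbers stand for stronger inhibition and higher numbers for weaker inhibition:

compound 1 `CC1=C(C(=O)SC(C)(C)C)C(c2ccccc2)C=C(c2ccccc2)N1` gives 95800 nM
compound 2 `CCOC(=O)C1=C(C)NC(c2ccccc2)=CC1c1ccc(OC)cc1` gives 29800 nM

Compound 2 stands lowest of the two numbers; compound 1 gives a higher number, and the gap lies beyond the scatter. Compound 3 `COc1ccc(C2C=C(c3ccccc3)NC(C)=C2C(=O)SC(C)(C)C)cc1` awaits measurement in this assay. It differs from compound 2 in one place: (tert-butyl)sulfanyl in place of ethoxy on a carbonyl carbon. For the measured compounds named here, no pair of measured compounds isolates this change; compound 1 carries the same (tert-butyl)sulfanyl group but differs from compound 2 in a second place as well. A modest weakening is expected, a 1.8-fold higher number from compound 2 to compound 3 (0.27 log units; within the scatter), near the edge of the scatter. For compound 3 in this assay the estimate is 55000 nM, expected range 15000 nM to 180000 nM.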

Compound 3, half-maximal inhibitory concentration: 26800 nM
Beside the measured number, compound 3's estimate is 2.1-fold (0.31 log units) above it; the measured number falls inside the stated range.
By their numbers in this assay, from the lowest: compounds 3 and 2 (each within the scatter of the next); then compound 1.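

In this assay the swap of ethoxy for (tert-butyl)sulfanyl on a carbonyl carbon gives a 1.1-fold lower number from compound 2 to compound 3 (0.05 log units; within the scatter) and so leaves the read-out unmoved, with a larger group of five heavy atoms in place of three. With (tert-butyl)sulfanyl held, methoxy in place of hydrogen on an aromatic carbon gives a 3.6-fold lower number from compound 1 to compound 3 (0.55 log units; beyond the scatter) as the first single-place read of that aromatic position.

On these data alone, whether an amine or a carboxylic acid on that carbonyl carbon would read the same stays open. Nothing at hand explains either step.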